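The source may hold more compounds than are shown below. What is called first, only, known or untested is meant among the compounds shown, and "the series" means these compounds.

Working notes on the series.

The shared core is carried by compound 1 `CCc1nn(C)c(CO/N=C/c2c(C)nn(C)c2Oc2ccc(Cl)cc2)c1Cl`, compound 2 `CCc1nn(C)c(CO/N=C/c2c(C)nn(C)c2Oc2cccc(Cl)c2)c1Cl` and compound 3 `CCc1nn(C)c(CO/N=C/c2c(C)nn(C)c2Oc2ccc(Br)cc2)c1Cl`; the three differ only in the group on the oxygen on an aromatic ring. In a functional assay on SMMC-7721 cells (Homo sapiens) for inhibition, read by MTT assay, with a stated time of 72 h, tested at 25 uM (a higher number here means more inhibition at the concentration tested (going by the name of the read-out), a lower number less inhibition), compound 1 gives < 80%, which is a limit of the assay and not a number. In this assay compound 2 gives < 80%, again a limit. Compound 3 stands in this assay at < 80%, also a limit. The steps a step that the two limits leave unreadable from compound 1 to compound 2, a step that the two limits leave unreadable from compound 1 to compound 3 and a step that the two limits leave unreadable from compound 2 to compound 3 therefore have no readable size, because of the limit of < 80% in this assay, at which 3 of the 3 values shown sit. Nothing in these three values separates compound 3 from compound 1 or compound 2 in this assay.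

Compound 4 `CCc1nn(C)c(CO/N=C/c2c(C)nn(C)c2Oc2ccccc2C)c1Cl` is not yet measured in this assay. The change from compound 3 to compound 4 is 2-methylphenyl in place of 4-bromophenyl on an oxygen on an aromatic ring. The measured steps that touch the same place, from compound 1 to compound 2, from compound 1 to compound 3 and from compound 2 to compound 3, all sit between values at the limit and give no direction or size. For compound 4 in this assay the expected value is 40%, with a range from 10% to 75%. The expected step is a step that the limit leaves unreadable from compound 3 to compound 4, most likely again returned only as a limit rather than a number.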

Compound 4, a percentage reported as inhibition, at one concentration (the size of the read-out at that concentration, not a potency): < 80%
Compound 4 ended at the assay's limit (the forecaster's own chance of this, stated with the estimate: 80%); the middle value does not contradict the limit.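

The steps joining compound 4 to compound 1, compound 2 and compound 3 in this assay cannot be read, because all four values are limits and not numbers: the limit of < 80% in this assay, at which 4 of the 4 values shown sit.

The compounds shown leave open how far any of the four stands from the others, and whether the group on the oxygen on an aromatic ring changes the inhibition at all.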